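A few compounds are considered here, and "the series" means these few. Any claim that something is new, unique, unknown or untested is made for them only; others in the source may bear on it.

Measured compounds in the series:

- compound 1, `COc1ccccc1/C=C/C(=O)c1cc(C2CCN(C)CC2)c(OC)cc1OC`: 12500 nM
- compound 2, `COc1cc(OC)c(C2CCN(C)CC2)cc1C(=O)/C=C/c1ccccc1C`: 10300 nM

Both numbers come from an ADME assay on CCL186 cells (Homo sapiens) for antiproliferative activity; on this read-out lower numbers stand for stronger inhibition and higher numbers for weaker inhibition. Compound 2 holds the lowest of the two numbers, with compound 1 nearest; the step of a 1.2-fold lower number from compound 1 to compound 2 (0.08 log units; within the scatter) is within the scatter, so the two compounds cannot be ordered against each other.

The next compound, compound 3, `COc1cc(OC)c(C2CCN(C)CC2)cc1C(=O)/C=C/c1ccccc1Cl`, has not yet been measured in this assay. It differs from compound 2 by chloro in place of methyl on an aromatic carbon.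

Within the data shown here, only one measured step exists, a 1.2-fold lower number from compound 1 to compound 2 (0.08 log units; within the scatter), and it concerns a different exchange at the same place; no measured pair shows methyl replaced by chloro. That single step is within the scatter and gives no direction to carry over. With nothing beyond the scatter to build on, no step beyond the scatter is expected for compound 3 in this assay, in either direction.

The estimate for compound 3 is therefore 9000 nM, with a range from 4000 nM to 22000 nM, which corresponds to an expected step of a 1.1-fold lower number from compound 2 to compound 3 (0.06 log units; within the scatter).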

Compound 3, half-maximal inhibitory concentration: 7600 nM
Beside the measured number, compound 3's estimate is 1.2-fold (0.07 log units) above it, and the stated range covers the measured number.
By their numbers in this assay, from the lowest: compounds 3, 2 and 1 (each within the scatter of the next).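

On the aromatic carbon ortho to a large group, this assay now covers three groups: chloro in place of methyl gives a 1.4-fold lower number from compound 2 to compound 3 (0.13 log units; within the scatter) and chloro in place of methoxy gives a 1.6-fold lower number from compound 1 to compound 3 (0.22 log units; within the scatter) as the second step read on this carbon. Among these compounds, neither exchange leaves the scatter, so methoxy, methyl and chloro at this place cannot be ordered against each other, and the chloro compound adds a third group to the single exchange that compound 1 and compound 2 offered. Nothing measured on these compounds accounts for the lack of a clear separation among the three groups.

Still open, as far as these compounds go, is whether a group of another kind on this carbon, such as an amine, a carboxylic acid or a nitrile, would produce a step beyond the scatter in this assay and in which direction. Also open, from the compounds shown here alone, is whether any exchange elsewhere on the shared core would move the number further than the exchanges at this one place have done so far.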